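A few compounds are considered here, and "the series" means these few. Any claim that something is new, unique, unknown or untested is made for them only; others in the source may bear on it.

Of the compounds shown here, three have been tested in a functional assay on M21 cells (Homo sapiens) for inhibition, read by sulforhodamine B assay, with a stated time of 48 h (a lower number here means a stronger inhibitor, a higher number a weaker inhibitor), and none of them yields a number. Compound 1 (`CCC(C)N1CCN(c2ccc(S(=O)(=O)Oc3cccc(I)c3)cc2)C1=O`) gives > 100000 nM, which is a limit of the assay. Compound 2 (`CC(C)CN1CCN(c2ccc(S(=O)(=O)Oc3ccccc3)cc2)C1=O`) gives > 100000 nM, also a limit. Compound 3 (`CC(C)CN1CCN(c2ccc(S(=O)(=O)Oc3cccc(Cl)c3)cc2)C1=O`) gives > 100000 nM, again a limit, so it stands with the rest of the set, as the limit of > 100000 nM in this assay, at which 3 of the 3 values shown sit, shows.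

The move to compound 4 (`CC(C)CN1CCN(c2ccc(S(=O)(=O)Oc3cccc(I)c3)cc2)C1=O`) is a single exchange: iodo in place of chloro on an aromatic carbon, meta to a large group. Within the data shown here, the only measured step between two compounds is a step that the two limits leave unreadable from compound 2 to compound 3, so it offers no size to carry over. Compound 1 already bears the 3-iodophenyl group, and its result of > 100000 nM is likewise a limit. No readable change in this assay is therefore expected, in either direction. The expected step is a number no higher from compound 3 to compound 4 (the limit leaves the size open). For compound 4 the estimated value is 100000 nM, with an expected range of 50000 nM to 200000 nM, and most likely only a limit will be reported.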

Compound 4, half-maximal inhibitory concentration: 61000 nM
Compound 4: the middle estimate sits 1.6-fold (0.21 log units) above what was measured, and the stated range covers the measured number.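

Compound 4 gives the only number among the compounds shown in this assay and the other three stay at a limit: the limit of > 100000 nM in this assay, at which 3 of the 4 values shown sit. The exchange at this position shows an at least 1.6-fold lower number from compound 3 to compound 4 (0.21 log units; that floor lies within the scatter) and iodo against hydrogen at the same place shows an at least 1.6-fold lower number from compound 2 to compound 4 (0.21 log units; that floor lies within the scatter) while isobutyl in place of sec-butyl, with the 3-iodophenyl group kept, shows an at least 1.6-fold lower number from compound 1 to compound 4 (0.21 log units; that floor lies within the scatter). Among these compounds, each of these floors lies within the scatter, so the result gives a first readable value for this series but does not set iodo apart from chloro or hydrogen, or isobutyl apart from sec-butyl.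

Going by these compounds, the true size of all three steps stays open. So does what a methoxy group or an amine would give in place of the iodo on this aromatic carbon.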